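The source may report more compounds than this note shows. Statements on the series, on what has been measured and on what is new or still open speak of the compounds shown alone.

For the measured compounds named here, compound 1 `COc1ccc([C@@H]2CC(=O)c3c(O)cc(OCc4cn(Cc5ccc(Cl)cc5)nn4)cc3O2)cc1O` gives 17800 nM in a functional assay on RAW264.7 cells (Mus musculus) for inhibition, read by Griess assay, with stated times of 2 h and 24 h (on this read-out higher numbers stand for weaker inhibition and lower numbers for stronger inhibition), the highest of the three numbers so far. Going by the values given here, compound 2 `COc1ccc([C@@H]2C/C(=N\O)c3c(O)cc(OCc4cn(Cc5ccccc5F)nn4)cc3O2)cc1O` gives 5710 nM, and compound 3 `CCCn1cc(COc2cc(O)c3c(c2)O[C@H](c2ccc(OC)c(O)c2)C/C3=N\O)nn1` gives 2340 nM; the only single-site step among them, a 2.4-fold lower number from compound 2 to compound 3 (0.39 log units; beyond the scatter), alters the group on a saturated chain carbon bound to an aromatic nitrogen. Compound 4 `COc1ccc([C@@H]2CC(=O)c3c(O)cc(OCc4cn(Cc5ccccc5C(F)(F)F)nn4)cc3O2)cc1O` differs from compound 1 at that same place: 2-(trifluoromethyl)phenyl in place of 4-chlorophenyl on a saturated chain carbon bound to an aromatic nitrogen. Among the compounds with values here, no measured step exchanges one such ring-bearing group for another there, and no single step joins compound 1 to compound 2, so the guidance is thin. Compound 4 is therefore expected to move only a 1.2-fold lower number from compound 1 to compound 4 (0.07 log units; within the scatter), within the scatter. Compound 4 is estimated at 15000 nM, with a range from 6000 nM to 40000 nM.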

Compound 4, half-maximal inhibitory concentration: 12500 nM
For compound 4 the middle estimate is 1.2-fold (0.08 log units) above the measured one; measured number inside the range.
By their numbers in this assay, from the lowest: compound 3; then compound 2; then compounds 4 and 1 (each within the scatter of the next).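

In this assay, 2-(trifluoromethyl)phenyl in place of 4-chlorophenyl gives a 1.4-fold lower number from compound 1 to compound 4 (0.15 log units; within the scatter). For the compounds shown here, this is the first step at this place that exchanges one ring-bearing group for another, and on this evidence compound 1 and compound 4 cannot be told apart. No measurement shown bears on this result.

The compounds shown leave open whether the ethyl exchange seen in a 2.4-fold lower number from compound 2 to compound 3 (0.39 log units; beyond the scatter) would read the same on the core of compound 1. They also leave open how an amine or a carboxylic acid at this place would read.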